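A few compounds are considered here, and "the series" means these few. Any claim that something is new, unique, unknown or untested is made for them only; others in the source may bear on it.

Compound 1 `COc1ccc(C)cc1NC(=O)CSc1nnc(-c2ccoc2C)n1Cc1ccco1`: 15.9 nM
Compound 2 `Cc1occc1-c1nnc(SCC(=O)Nc2ccc(F)c(Cl)c2)n1Cc1ccco1`: 39.8 nM
Compound 3 `Cc1occc1-c1nnc(SCC(=O)Nc2ccc(Cl)cc2)n1Cc1ccco1`: 100 nM

In a functional assay on CHO cells for antagonist activity at Orexin receptor type 2 (Homo sapiens), read by FLIPR and calcium flux (a higher number here means a weaker inhibitor, a lower number a stronger inhibitor), compound 3 gives the highest of the three numbers; compound 2 is nearest and compound 1 furthest, as the steps of a 2.5-fold higher number from compound 2 to compound 3 (0.40 log units; beyond the scatter) and a 6.3-fold higher number from compound 1 to compound 3 (0.80 log units; beyond the scatter) show. Compound 4 `CC(=O)c1cccc(NC(=O)CSc2nnc(-c3ccoc3C)n2Cc2ccco2)c1` carries the change (3-acetylphenyl in place of 4-chlorophenyl on an amide-type nitrogen). For the measured compounds named here, the steps that bear on it are the two aryl swaps on the same nitrogen, a 6.3-fold higher number from compound 1 to compound 3 (0.80 log units; beyond the scatter) and a 2.5-fold higher number from compound 2 to compound 3 (0.40 log units; beyond the scatter), both modest. Going by the values given here, no measured pair involves an acetyl group, so the direction is open. Compound 4 is expected to give 60 nM, with a range from 15 nM to 250 nM, a step of a 1.7-fold lower number from compound 3 to compound 4 (0.22 log units; within the scatter) that is estimated to stay within the modest sizes seen.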

Compound 4, inhibition constant: 316 nM
Compound 4: the middle estimate sits 5.3-fold (0.72 log units) below what was measured, outside the stated range (above it).
By their numbers in this assay, from the lowest: compound 1; then compound 2; then compound 3; then compound 4.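

In this assay, for the compounds shown here, 3-acetylphenyl on the amide-type nitrogen gives the highest number of the four compounds, with a 3.2-fold higher number from compound 3 to compound 4 (0.50 log units; beyond the scatter), a 7.9-fold higher number from compound 2 to compound 4 (0.90 log units; beyond the scatter) and a 20-fold higher number from compound 1 to compound 4 (1.30 log units; beyond the scatter), the last of these the only large step. Aryl swaps at this one position therefore span a wider range than the earlier compounds showed, and the acetyl-bearing ring lies at its weak end. Nothing measured here accounts for this change. The compounds shown leave open how 4-acetylphenyl would compare, and what a phenyl ring carrying an amine or a carboxylic acid would give at this position.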